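A few compounds are considered here, and "the series" means these few. Any claim that something is new, unique, unknown or untested is made for them only; others in the source may bear on it.

Three compounds have been measured in a toxicity assay on mitochondria from liver (Rattus norvegicus) for inhibition, in the presence of a further agent that is not named here (a lower number here means a stronger inhibitor, a higher number a weaker inhibitor), so far:

compound 1 `Cc1c(C)n(C(=O)c2ccc(O)c(C#N)c2)c2ccccc12` gives 3600 nM
compound 2 `N#Cc1cc(C(=O)N2CCc3ccccc32)cc(I)c1O` gives 53000 nM
compound 3 `CSc1cc(C(=O)N2CCc3ccccc32)cc(C#N)c1O` gives 40000 nM

Among these, compound 3 and compound 2 lie within the scatter of each other, so no order can be drawn between them. Both have higher numbers than compound 1, which stands apart from this pair at 3600 nM.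

The next compound is compound 4 `CC(C)(C)c1cc(C(=O)N2CCc3ccccc32)cc(C#N)c1O`, which has tert-butyl in place of methylsulfanyl on an aromatic carbon, ortho to a hydroxy group and meta to a cyano group (tert-butyl in place of methylsulfanyl on an aromatic carbon). For the measured compounds named here, one measured step bears on this change, as it concerns the same aromatic carbon. Exchanging iodo for methylsulfanyl gave a 1.3-fold lower number from compound 2 to compound 3 (0.12 log units; within the scatter), so that exchange left this assay within the scatter. Going by the values given here, no measured compound carries tert-butyl, so this single step is the only guide, and it is a thin one. A step within the scatter is therefore expected, with only a slight lean towards a lower number. The expected step is a 1.3-fold lower number from compound 3 to compound 4 (0.12 log units; within the scatter). For compound 4 the estimated value is 30000 nM, with an expected range from 10000 nM to 70000 nM.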

Compound 4, half-maximal inhibitory concentration: 6600 nM
For compound 4 the middle estimate is 4.5-fold (0.66 log units) above the measured one, outside the stated range (below it).
By their numbers in this assay, from the lowest: compounds 1 and 4 (each within the scatter of the next); then compounds 3 and 2 (each within the scatter of the next).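

In this assay, the aromatic carbon ortho to a hydroxy group and meta to a cyano group proves sensitive to the group it carries, which the earlier exchange of iodo for methylsulfanyl (a 1.3-fold lower number from compound 2 to compound 3 (0.12 log units; within the scatter)) had not shown. Tert-butyl in place of methylsulfanyl gives a 6.1-fold lower number from compound 3 to compound 4 (0.78 log units; beyond the scatter), and tert-butyl in place of iodo gives an 8.0-fold lower number from compound 2 to compound 4 (0.90 log units; beyond the scatter), so tert-butyl stands apart from both groups that lie within the scatter of each other. With 4 heavy atoms, all carbon, and 0 hydrogen-bond acceptors, tert-butyl differs in its counts from methylsulfanyl, but nothing measured here accounts for the lower number.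

The compounds shown leave open whether smaller or differently shaped carbon groups at this place, such as methyl, isopropyl or cyclopropyl, would follow tert-butyl, and whether an amine or a methoxy group would stay with methylsulfanyl and iodo. They also leave open whether tert-butyl would give a step of similar size on the core of compound 1, which carries only hydrogen at this place.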